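The compounds below may be only part of what the source reports. "The series", "measured", "known", "first", "only" and "open" are said of these compounds alone.

Compound 1 `O=C(/C(=C\c1ccc(Cl)c([N+](=O)[O-])c1)S(=O)(=O)c1ccc(Br)cc1)c1ccc(Br)cc1` carries a (4-bromophenyl)sulfonyl on the double-bonded chain carbon of the shared core, and in a functional assay on DU-145 cells (Homo sapiens) for inhibition, read by trypan blue exclusion, with a stated time of 96 h (on this read-out higher numbers stand for weaker inhibition of growth and lower numbers for stronger inhibition of growth), compound 1 gives 10000 nM. Compound 3 `O=C(/C(=C\c1ccc(Cl)c([N+](=O)[O-])c1)Sc1ccc(Br)cc1)c1ccc(Br)cc1` is the sulfanyl counterpart, and in this assay compound 3 gives 10000 nM. Among the compounds with values here, the one single-point step measured so far is no change at the digits printed from compound 1 to compound 3 (within the scatter). Compound 2 `Cc1ccc(S/C(=C/c2ccc(Cl)c(Cl)c2)C(=O)c2ccc(Br)cc2)cc1` gives 50000 nM in this assay; it differs from compound 3 at two places, so its value is read only as it stands. Compound 1 therefore sits level with compound 3 at the lowest number of the three, with compound 2 furthest away.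

Compound 4 `O=C(/C(=C\c1ccc(F)cc1F)S(=O)(=O)c1ccc(Br)cc1)c1ccc(Br)cc1` is the next step from compound 1: 2,4-difluorophenyl in place of 4-chloro-3-nitrophenyl on a double-bonded chain carbon bound to a double-bonded chain carbon. Within the data shown here, the measured step from compound 1 to compound 3 alters the (4-bromophenyl)sulfonyl, not the aryl on the double-bonded chain carbon, so no measured step bears directly on the change to compound 4. Compound 2 carries a different aryl there together with a second alteration and reaches a higher number, but the two changes cannot be separated. The step to compound 4 is therefore expected to be a 1.5-fold higher number from compound 1 to compound 4 (0.18 log units; within the scatter), nothing beyond the scatter, with a lean toward a weaker read. Compound 4 is estimated at 15000 nM, within 5000 nM to 50000 nM.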

Compound 4, concentration for 50% growth inhibition: 7500 nM
Compound 4: middle estimate off by 2.0-fold (0.30 log units), on the high side, within the range that was stated.
By their numbers in this assay, from the lowest: compounds 4, 1 and 3 (each within the scatter of the next); then compound 2.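

Within the data shown here, on the double-bonded chain carbon bound to a double-bonded chain carbon, 2,4-difluorophenyl replaces 4-chloro-3-nitrophenyl in this assay with a 1.3-fold lower number from compound 1 to compound 4 (0.12 log units; within the scatter), the first measured step at this position, as the earlier step altered only the (4-bromophenyl)sulfonyl. With the nitrogen, oxygen and chlorine of the leaving group gone and fluorine present instead, the read-out stays within the scatter, so in this sulfonyl compound those atoms are not required to keep growth inhibition at the level of compound 1. No accompanying measurement bears on why the read-out holds across this change.

Open is whether the same aryl exchange holds in the sulfanyl compound 3, since the two compounds shown at this step both carry the (4-bromophenyl)sulfonyl. Also open, from the compounds shown here alone, is whether any group at this position moves the number beyond the scatter, for example a phenyl ring bearing an amine or a carboxylic acid, or a longer alkyl chain in place of the aryl ring.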